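This account rests on a few compounds, and the source may have more. Where it says the series, first, only, none or still open, it means among the compounds named here.

Among the compounds with values here, compound 3 `Cc1cc(CN2CCN(c3cccc4[nH]c(-c5ccc(C(C)(C)C)cc5)nc34)CC2)nn1C` gives 83 nM in an assay on isolated protein for displacement of a labelled ligand from Gonadotropin-releasing hormone receptor (Homo sapiens) (on this read-out higher numbers stand for weaker inhibition and lower numbers for stronger inhibition), the highest number of the three measured so far; compound 1 `Cc1nc(C)c(CN2CCN(c3cccc4[nH]c(-c5ccc(C(C)(C)C)cc5)nc34)CC2)o1` gives 31 nM and compound 2 `Cc1nc(C)c(CN2CCN(c3cccc4[nH]c(-c5ccc(C(C)(C)C)cc5)nc34)CC2)s1` gives 27 nM. Compound 4 `CCn1cc(CN2CCN(c3cccc4[nH]c(-c5ccc(C(C)(C)C)cc5)nc34)CC2)nc1C` differs from compound 3 by 1-ethyl-2-methyl-1H-imidazol-4-yl in place of 1,5-dimethyl-1H-pyrazol-3-yl on a saturated chain carbon bound to an amine nitrogen in a ring. Within the data shown here, no measured step exchanges a pyrazole for an imidazole, but a 2.7-fold higher number from compound 1 to compound 3 (0.43 log units; beyond the scatter) and a 3.1-fold higher number from compound 2 to compound 3 (0.49 log units; beyond the scatter) show that placing the pyrazole there gave a modest rise, while a 1.1-fold lower number from compound 1 to compound 2 (0.06 log units; within the scatter) shows that exchanging one five-membered aromatic ring with 2 hetero atoms for another can leave the number unchanged. For compound 4 a step of a 1.7-fold lower number from compound 3 to compound 4 (0.22 log units; within the scatter) is therefore expected, a modest fall at most. Compound 4 is estimated at 50 nM, with a range from 20 nM to 150 nM.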

Compound 4, half-maximal inhibitory concentration: 10 nM
The estimate for compound 4 lay 5.0-fold (0.70 log units) above the measured number; the whole stated range lies above it.
By their numbers in this assay, from the lowest: compound 4; then compounds 2 and 1 (each within the scatter of the next); then compound 3.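

In this assay, within the data shown here, the place on a saturated chain carbon bound to an amine nitrogen in a ring proves more responsive than the earlier compounds showed: 1-ethyl-2-methyl-1H-imidazol-4-yl gives the lowest number of the four, against the pyrazole (an 8.3-fold lower number from compound 3 to compound 4 (0.92 log units; beyond the scatter)), the thiazole (a 2.7-fold lower number from compound 2 to compound 4 (0.43 log units; beyond the scatter)) and the oxazole (a 3.1-fold lower number from compound 1 to compound 4 (0.49 log units; beyond the scatter)). Exchanging one five-membered aromatic ring with 2 hetero atoms for another can therefore leave the number unchanged, raise it or lower it. No measurement shown accounts for the fall. Going by these compounds, whether the step belongs to the imidazole ring itself or to its ethyl group remains open. So does the reading of a propyl chain in place of that ethyl group.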